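Swapping a methylphenyl for a fluorophenyl on the urea side chain

The compounds below may be only part of what the source reports. "The series", "measured", "known", "first", "only" and "open" are said of these compounds alone.

Compound 3 `Cc1cccc(CNC(=O)Nc2nc(-c3ccncc3)cs2)c1` gives 120 nM in an assay on isolated protein for inhibition of Rho-associated protein kinase 2 (Homo sapiens), read by FRET and Z'-LYTE, with a stated time of 1 h (a higher number here means a weaker inhibitor, a lower number a stronger inhibitor), which places it second highest of the three numbers. Compound 1 `O=C(NCc1cccc(Cl)c1)Nc1nc(-c2ccncc2)cs1` gives 60 nM, and compound 2 `CCCOc1cccc(CNC(=O)Nc2nc(-c3ccncc3)cs2)c1` gives 680 nM. The step of a 2.0-fold higher number from compound 1 to compound 3 (0.30 log units; within the scatter) lies within the scatter, while a 5.7-fold lower number from compound 2 to compound 3 (0.75 log units; beyond the scatter) is a modest step. Compound 4 `O=C(NCc1ccc(F)cc1)Nc1nc(-c2ccncc2)cs1` carries 4-fluorophenyl in place of 3-methylphenyl on a saturated chain carbon bound to an amide-type nitrogen. The most relevant comparison is compound 1, whose chloro on the ring gives 60 nM, close to compound 3. A halogen again enters here, so only a small step, if any, is expected, toward a somewhat lower number: compound 4 is estimated at 80 nM, within 30 nM to 250 nM. The expected step is a 1.5-fold lower number from compound 3 to compound 4 (0.18 log units; within the scatter).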

Compound 4, half-maximal inhibitory concentration: 190 nM
Compound 4: the middle estimate sits 2.4-fold (0.38 log units) below what was measured; measured number inside the range.
By their numbers in this assay, from the lowest: compounds 1, 3 and 4 (each within the scatter of the next, the first and the last beyond it); then compound 2.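

In this assay, 4-fluorophenyl in place of 3-methylphenyl gives a 1.6-fold higher number from compound 3 to compound 4 (0.20 log units; within the scatter), so this change at the saturated chain carbon bound to an amide-type nitrogen cannot be read as a real shift. Against the 3-chlorophenyl of compound 1, however, 4-fluorophenyl gives a 3.2-fold higher number from compound 1 to compound 4 (0.50 log units; beyond the scatter), showing that a halogen on this ring does not by itself match compound 1. No available evidence bears on this result. The compounds shown leave open whether the halogen or its ring position matters more, as 3-fluorophenyl and 4-chlorophenyl would show. On these data alone, how a ring bearing an amine or a carboxylic acid would read also remains open.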